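A few compounds are considered here, and "the series" means these few. Any claim that something is new, unique, unknown or untested is made for them only; others in the source may bear on it.

Measured so far:
- compound 1 `CCO/N=C/Nc1cc(Cl)cc(Cl)c1`, in a physicochemical assay for lipophilicity, measured as octanol-water partition (on this read-out lower numbers stand for lower lipophilicity and higher numbers for higher lipophilicity), compound 1 gives 3
- compound 2 `C#CCc1c(Cl)cc(N/C=N/OCCCC)cc1Cl`, in this assay compound 2 gives 4.4

Compound 2 stands highest of the two numbers in this assay. Going by the values given here, its nearest neighbour is compound 1, whose value lies lower by a gap beyond the scatter, but the two structures differ in more than one place, so no single step between them is counted; only the two values themselves are on hand.

The next compound, compound 3 `C#CCc1c(Cl)cc(N/C=N/OCc2ccccc2)cc1Cl`, is not yet measured in this assay. It differs from compound 2 in one place: phenyl in place of propyl on a saturated chain carbon bound to an oxygen. Among the compounds with values here, no step between measured compounds is counted for this kind of change, so the expectation rests on the structures alone. Phenyl in place of propyl on a saturated chain carbon bound to an oxygen is expected to move this assay upward by a small step, at most a little beyond the scatter, and the expected step is a number 0.40 log units higher from compound 2 to compound 3 (beyond the scatter). Compound 3 is therefore estimated at 4.8, within a range from 4.4 to 5.3.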

Compound 3, partition coefficient: 4.2
Compound 3: middle estimate off by 0.60 log units, on the high side; measured number outside the range, below it.
By their numbers in this assay, from the lowest: compound 1; then compounds 3 and 2 (each within the scatter of the next).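

Phenyl in place of propyl on a saturated chain carbon bound to an oxygen, which cut one bond further out reads as butyl to benzyl, gives the first single-place step in the series in this assay: a number 0.20 log units lower from compound 2 to compound 3 (within the scatter). Although 3 heavy atoms leave and 6 enter, along with a six-membered aromatic ring of carbon only, the values of this pair stay within the scatter, so in this pair the read-out does not separate the saturated chain from the aromatic ring at this place. Nothing on hand accounts for this result, and one pair gives no general rule for the position.

Still open, on these data alone, is whether this assay stays this close with other groups at this place, such as a longer chain like hexyl, or an amine or a carboxylic acid on the chain. The shorter chain of compound 1 offers no answer for chain length, since that compound differs from the others in more than one place.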